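From piperidin-1-yl to 2,3-dihydro-1H-indol-1-yl on a shared core

The source may report more compounds than this note shows. Statements on the series, on what has been measured and on what is new or still open speak of the compounds shown alone.

Among the measured compounds shown here, in a functional assay on A549 cells (Homo sapiens) for inhibition, read by MTT assay, with a stated time of 72 h (a higher number here means a weaker inhibitor, a lower number a stronger inhibitor), compound 1 (`c1cc(N2CCCCC2)nc(Nc2ccc(Oc3ncnc4sccc34)cc2)n1`) gives 4020 nM, the highest of the three numbers measured so far. Compound 3 (`CNC(=O)c1cc(Oc2ccc(Nc3nccc(N4CCCCC4)n3)cc2)ccn1`) gives 890 nM. Compound 2 (`COc1ccc(C[C@H]2C(=O)N[C@@H](C)C(=O)N(C)[C@H]3Cc4cccc(c4)Oc4cc(ccc4O)C[C@H](C(=O)N[C@H](C)C(=O)N[C@@H](C)C(=O)N2C)N(C)C3=O)cc1`), a structure of a quite different kind, gives 20 nM, the lowest of the three.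

Compound 4 (`c1ccc2c(c1)CCN2c1ccnc(Nc2ccc(Oc3ncnc4sccc34)cc2)n1`) has not yet been measured. It differs from compound 1 in one place: 2,3-dihydro-1H-indol-1-yl in place of piperidin-1-yl on an aromatic carbon. The 2,3-dihydro-1H-indol-1-yl takes the place of piperidin-1-yl on an aromatic carbon of a six-membered aromatic ring with 2 nitrogen, and the rest of the core of compound 1 stays as it is.

For the measured compounds named here, only one measured step starts from compound 1: a 4.5-fold lower number from compound 1 to compound 3 (0.65 log units; beyond the scatter). That modest step lies beyond the scatter, but it leaves the piperidin-1-yl untouched, so it bears only indirectly, as a guide to the size a single change has reached here. Going by the values given here, no measured step replaces the piperidin-1-yl, and the data therefore give no direction for this change. The expected change, a 1.2-fold lower number from compound 1 to compound 4 (0.09 log units; within the scatter), is accordingly small, with no step beyond the scatter expected. For compound 4 the estimated value in this assay is 3300 nM, with an expected range of 1000 nM to 10000 nM.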

Compound 4, half-maximal inhibitory concentration: "not active" (no number reported)
For compound 4 the study gives words and no number, so the estimate cannot be set against anything.
By their numbers in this assay, from the lowest: compound 2; then compound 3; then compound 1.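

In this assay, among the compounds shown here, compound 4 is reported only in words, as not active, without a number, so no step from compound 1 can be read from it. Nothing shown here offers an explanation for this result. The compounds shown leave open how far 2,3-dihydro-1H-indol-1-yl in place of piperidin-1-yl shifts the number on this shared core.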